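Furan-3-yl for benzyl: a first expectation

The source may report more compounds than this note shows. Statements on the series, on what has been measured and on what is new or still open speak of the compounds shown alone.

In a functional assay on the whole organism with Mus musculus as the target (a lower number here means that less compound is needed, a higher number that more compound is needed for the effect), compound 1 (`C[C@@H](NCc1ccc(SCc2ccccc2)cc1)C(N)=O`) gives 24.8 mg/kg as its dose for half-maximal effect and compound 2 (`C[C@@H](NCc1ccc(OCCc2ccccc2)cc1)C(N)=O`) gives 24.9 mg/kg on the same read-out. These two values lie within the scatter of each other, so compound 2 stands level with compound 1. Going by the values given here, the series offers no measured step at a single site to serve as a direct guide.

Compound 3 (`C[C@@H](NCc1ccc(OCc2ccoc2)cc1)C(N)=O`) has furan-3-yl in place of benzyl on a saturated chain carbon bound to an oxygen on an aromatic ring. With so little to go on, no step beyond the scatter is expected in this assay, with only a slight lean towards a higher number (a 1.2-fold higher number from compound 2 to compound 3 (0.08 log units; within the scatter)). The estimated value for compound 3 is 30 mg/kg within an expected range from 13 mg/kg to 70 mg/kg for this read-out.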

Compound 3, dose for half-maximal effect: 152 mg/kg
Compound 3: the middle estimate sits 5.1-fold (0.70 log units) below what was measured, outside the stated range (above it).
By their numbers in this assay, from the lowest: compounds 1 and 2 (each within the scatter of the next); then compound 3.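

In this assay, the place on a saturated chain carbon bound to an oxygen on an aromatic ring proves sensitive: furan-3-yl in place of benzyl gives a 6.1-fold higher number from compound 2 to compound 3 (0.79 log units; beyond the scatter). Going by these compounds alone, this is the first measured step at a single site. It shows that exchanging seven heavy atoms and a six-membered aromatic ring of carbon only for five heavy atoms and a five-membered aromatic ring with 1 hetero atom is not neutral in this whole-organism read-out. Nothing at hand bears on what lies behind the step.

Still open, from the compounds shown here alone, is whether the step follows the furan-3-yl ring itself or the smaller group as a whole. Phenyl or thiophen-3-yl at this place would help separate the two.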